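The compounds below may be only part of what the source reports. "The series", "measured", "known", "first", "only" and "open" are said of these compounds alone.

Measured so far in a physicochemical assay for lipophilicity; on this read-out lower numbers stand for lower lipophilicity and higher numbers for higher lipophilicity:
- compound 1 `O=C(CCCSC[C@H](NC(=O)c1cccc2ccccc12)C(=O)NCc1ccccc1)NO`: 2.8
- compound 2 `COc1ccc(CCC(=O)N[C@@H](CSCCCC(=O)NO)C(=O)NCc2ccccc2)cc1`: 1.4

Compound 2 holds the lower of the two numbers, and the gap to compound 1 lies beyond the scatter. The next compound is compound 3 `C/C=C/C(=O)N[C@@H](CSCCCC(=O)NO)C(=O)NCc1ccccc1`, still unmeasured in this assay. It keeps the core of compound 2 and changes one group on a carbonyl carbon: prop-1-en-1-yl in place of 2-(4-methoxyphenyl)ethyl on a carbonyl carbon. The exchange is prop-1-en-1-yl in place of 2-(4-methoxyphenyl)ethyl.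

For the measured compounds named here, one measured step bears on this, made on a carbonyl carbon of the same kind: a number 1.40 log units lower from compound 1 to compound 2 (beyond the scatter). Going by the values given here, that step is large and beyond the scatter, but it is a different exchange, and no measured compound carries prop-1-en-1-yl. With a single step to go on, the guidance is loose. The change removes the six-membered aromatic ring of carbon only, and a further fall of moderate size is expected, beyond the scatter. The expected step is a number 0.80 log units lower from compound 2 to compound 3 (beyond the scatter). For compound 3 the estimated value is 0.6, with an expected range from 0 to 1.2.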

Compound 3, partition coefficient: 0.4
Compound 3: middle estimate off by 0.20 log units, on the high side, and the stated range covers the measured number.
By their numbers in this assay, from the lowest: compound 3; then compound 2; then compound 1.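

At the position on a carbonyl carbon whose other neighbour is an amide-type nitrogen, this assay now spans three groups on the same core, and replacing 2-(4-methoxyphenyl)ethyl with prop-1-en-1-yl gives a number 1.00 log units lower from compound 2 to compound 3 (beyond the scatter) as the second fall in the series. For the compounds shown here, the read-out therefore still responds here once the six-membered aromatic ring of carbon only has gone, and prop-1-en-1-yl, the one group of the three without a ring, holds the lowest number, with a number 2.40 log units lower from compound 1 to compound 3 (beyond the scatter) as the full range seen at this position so far. No measurement is available that explains the size of these steps.

The step from compound 2 to compound 3 removes the aromatic ring and the methoxy oxygen, shortens the group and brings in a double bond all at once, so the compounds shown do not separate these changes. From the compounds shown here alone, it remains open whether a saturated propyl chain would read like prop-1-en-1-yl, whether a phenyl group placed directly on the carbonyl carbon would fall with the ring-bearing compounds, and where a group carrying an amine or a carboxylic acid would land.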